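The source may hold more compounds than are shown below. What is called first, only, known or untested is meant among the compounds shown, and "the series" means these compounds.

In a functional assay on LNCaP cells (Homo sapiens) for antiproliferative activity, read by MTT assay, with a stated time of 96 h (on this read-out lower numbers stand for stronger inhibition and higher numbers for weaker inhibition), compound 1 `FC(F)(F)Oc1cccc(Nc2nnnc3ccc(N4CCC(N5CCCCC5)CC4)nc23)c1` gives 4900 nM as a measured number. Compound 2 `CC(C)(C)OC(=O)N1CCC(CNc2ccc3nnnc(Nc4cccc(OC(F)(F)F)c4)c3n2)CC1` gives > 100000 nM as a limit of the assay and not a number. Compound 2 therefore has no measured place on the scale beyond that limit. Compound 3 `FC(F)(F)Oc1cccc(Nc2nnnc3ccc(NCC4CCNCC4)nc23)c1` differs from compound 2 by a single change, hydrogen in place of tert-butoxycarbonyl on an amine nitrogen in a ring. Going by the values given here, no measured pair of compounds in this assay shows what this change does, so any expectation remains loose. Among the compounds with values here, it rests on compound 1 at 4900 nM as the only number available, and a move toward stronger inhibition, beyond the usual scatter, is expected. An estimated change an at least 12-fold lower number from compound 2 to compound 3 (1.09 log units; beyond the scatter) is expected in that direction. Compound 3 is estimated at 8000 nM (expected range 1500 nM to 40000 nM).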

Compound 3, half-maximal inhibitory concentration: 11500 nM
Compound 3: middle estimate off by 1.4-fold (0.16 log units), on the low side; measured number inside the range.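

In this assay, replacing the tert-butoxycarbonyl on the amine nitrogen in the ring with hydrogen gives an at least 8.6-fold lower number from compound 2 to compound 3 (0.93 log units; beyond the scatter). Going by these compounds alone, this is the first measured pair to show what this change does at this position, and it moves the series from a limit of the assay to a measured number. The step can only be read as a bound, because compound 2 has a limit and not a number: the limit of > 100000 nM in this assay, at which 1 of the 3 values shown sits.

The compounds shown leave open how a small group on this same nitrogen, such as a methyl or an acetyl, would compare with the hydrogen of compound 3. Within the data shown here, only one pair carries this change, so they also leave open its true size and whether it would be repeated on another compound.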